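What a bare amide nitrogen might mean for compound 2

This account rests on a few compounds, and the source may have more. Where it says the series, first, only, none or still open, it means among the compounds named here.

Compound 1, `O=C1COc2ccc(-c3cnc(Cl)c(NS(=O)(=O)c4ccc(F)cc4)c3)cc2N1c1ccc(F)cc1`, gives > 40000 nM in a functional assay on HeLa cells (Homo sapiens) for antiproliferative activity, read by MTT assay, with a stated time of 72 h (on this read-out lower numbers stand for stronger inhibition and higher numbers for weaker inhibition), which is a limit of the assay rather than a number.
Compound 2, `O=C1COc2ccc(-c3cnc(Cl)c(NS(=O)(=O)c4ccc(F)cc4)c3)cc2N1c1ccc(Cl)cc1`, gives > 40000 nM, likewise a limit and not a number.
Compound 3, `COc1ncc(-c2ccc3c(c2)N(c2ccc(Cl)cc2)C(=O)CO3)cc1NS(=O)(=O)c1ccc(F)cc1`, gives 4830 nM.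

Compound 2 therefore stands at the limit, the point at which two of the three values sit (the limit of > 40000 nM in this assay, at which 2 of the 3 values shown sit); only compound 3 returns a number. The step that the two limits leave unreadable from compound 1 to compound 2 has both of its ends at that limit. Within the data shown here, the one readable step, an at least 8.2-fold lower number from compound 2 to compound 3 (0.91 log units; beyond the scatter), concerns a different position of the shared core, methoxy in place of chloro on an aromatic carbon.

Compound 4, `O=C1COc2ccc(-c3cnc(Cl)c(NS(=O)(=O)c4ccc(F)cc4)c3)cc2N1`, differs from compound 2 by hydrogen in place of 4-chlorophenyl on an amide-type nitrogen in a ring. Neither measured step touches the amide-type nitrogen in the ring, so the shown compounds say nothing about how large a step this change brings or in which direction. With compound 2 at a limit, any step short of a large drop in the number would still be reported as a limit. Compound 4 is expected to stay close to that limit, a step of a number no higher from compound 2 to compound 4 (the limit leaves the size open), with a real chance that only a limit is returned. The estimate for compound 4 is 40000 nM, in a range from 10000 nM to 120000 nM.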

Compound 4, half-maximal inhibitory concentration: 15600 nM
Estimate against measurement, compound 4: 2.6-fold (0.41 log units) above; measured number inside the range.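

Among these compounds, on the amide-type nitrogen in the ring, which no earlier step had touched, hydrogen in place of 4-chlorophenyl gives an at least 2.5-fold lower number from compound 2 to compound 4 (0.40 log units; beyond the scatter) in this assay, and hydrogen in place of 4-fluorophenyl gives an at least 2.5-fold lower number from compound 1 to compound 4 (0.40 log units; beyond the scatter). The position therefore bears on the read-out, the direction of the change is now known, and neither aromatic group on this nitrogen is needed for a measurable number on this core. The true size of both steps remains unknown, and the step between compound 1 and compound 2 cannot be read, because both of these compounds stop at a value that is a limit of the assay and not a number: the limit of > 40000 nM in this assay, at which 2 of the 4 values shown sit.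

On these data alone, what a methyl group, a longer alkyl chain or a chain ending in an amine would do on this nitrogen stays open, and so does whether the number depends on the size of the group placed there. Also open, as far as these compounds go, is whether methoxy in place of chloro on the aromatic carbon would lower the number in the same way when the amide hydrogen is present, as it is in compound 4.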